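A few compounds are considered here, and "the series" means these few. Any claim that something is new, unique, unknown or untested is made for them only; others in the source may bear on it.

Series notes. Compound 1 `NCCCNc1c(C(=O)NCc2ccc(F)cc2)nc(Br)c2cccnc12` and compound 2 `CN(C)c1ccc(CNC(=O)c2nc(Br)c3cccnc3c2N[C@H]2CC[C@H](N)CC2)cc1` share a core that carries a bromine, a secondary amide bearing a benzyl group, and an amine substituent; compound 1 has a fluorine on the benzyl ring and a 3-aminopropylamino chain, compound 2 a dimethylamino group on the benzyl ring and a cyclic diamine. In a functional assay on HCT-116 cells (Homo sapiens) for cytotoxicity, read by MTT assay, with a stated time of 72 h (on this read-out higher numbers stand for weaker inhibition and lower numbers for stronger inhibition), compound 1 gives only a limit, > 20000 nM, not a number. For compound 2 "not determined" (no result reported) in this assay. Going by the values given here, the series so far therefore offers no measured step and no single number; what stands is the limit of > 20000 nM in this assay, at which 1 of the 2 values shown sits.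

Compound 3 `CNCCCNc1c(C(=O)NCc2ccc(F)cc2)nc(Br)c2cccnc12` differs from compound 1 by methyl in place of hydrogen on an amine nitrogen. Among the compounds with values here, no pair of measured compounds shows the effect of such a change here, so the direction cannot be read from data. Since compound 1 gives > 20000 nM in this assay, a limit, the expectation is that the step from compound 1 to compound 3 is none beyond the scatter, expected as a step that the limit leaves unreadable from compound 1 to compound 3. Compound 3 is accordingly expected to give about 25000 nM in this assay, with a range from 8000 nM to 80000 nM, most likely again reported only as a limit.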

Compound 3, half-maximal inhibitory concentration: 9000 nM
Compound 3: middle estimate off by 2.8-fold (0.44 log units), on the high side, and the stated range covers the measured number.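

Methyl in place of hydrogen on an amine nitrogen gives an at least 2.2-fold lower number from compound 1 to compound 3 (0.34 log units; beyond the scatter) in this assay, so this nitrogen of the 3-aminopropylamino chain is a place where a change of one heavy atom moves the read-out beyond the scatter, and the series gains its first single number, with compound 3 at 9000 nM. Compound 1 gives > 20000 nM, which is a limit and not a number. The true size of the step stays unknown and only its direction and lower bound can be read, because one end of the pair is not a number: the limit of > 20000 nM in this assay, at which 1 of the 3 values shown sits.

The compounds shown leave open whether an ethyl group or a second methyl on this same nitrogen would carry the change further, hold it level or reverse it, and whether a longer chain in place of the 3-aminopropylamino chain would shift the read-out in this assay. Going by these compounds alone, they also leave open whether the step holds with a chlorine in place of the fluorine on the benzyl ring, as the single pair here speaks only for the core and benzyl group of compound 1.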